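A Second Fluorine on the Amide Ring

A few compounds are considered here, and "the series" means these few. Any claim that something is new, unique, unknown or untested is made for them only; others in the source may bear on it.

Compound 1 `[O-][S+](CCNC1CCN(Cc2ccc(F)cc2)CC1)C(c1ccc(F)cc1)c1ccc(F)cc1` gives 26.5 nM in an assay on membranes from Cortex for displacement of a labelled ligand from Sigma non-opioid intracellular receptor 1 (Cavia porcellus), read by scintillation counting, with a stated time of 120 min; on this read-out lower numbers stand for stronger inhibition and higher numbers for weaker inhibition.
Compound 2 `O=C(c1ccccc1)N1CCC(NCC[S+]([O-])C(c2ccc(F)cc2)c2ccc(F)cc2)CC1` gives 585 nM in this assay.
Compound 3 `O=C(c1ccccc1F)N1CCC(NCC[S+]([O-])C(c2ccc(F)cc2)c2ccc(F)cc2)CC1` gives 1310 nM in this assay.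

Compound 3 carries the highest number of the three and is therefore the weakest binder shown: the nearest is compound 2, as a 2.2-fold higher number from compound 2 to compound 3 (0.35 log units; beyond the scatter) shows, and the furthest is compound 1, as a 49-fold higher number from compound 1 to compound 3 (1.69 log units; beyond the scatter) shows. Compound 4 `O=C(c1ccc(F)cc1F)N1CCC(NCC[S+]([O-])C(c2ccc(F)cc2)c2ccc(F)cc2)CC1` differs from compound 3 by fluoro in place of hydrogen on an aromatic carbon. Among the measured compounds shown here, the one measured step of the same kind, a 2.2-fold higher number from compound 2 to compound 3 (0.35 log units; beyond the scatter), was modest and weakened binding. A change of that size, or none beyond the scatter, is therefore expected in this assay. Compound 4 is accordingly estimated at 2000 nM, between 900 nM and 4500 nM, which would mean an expected step of a 1.5-fold higher number from compound 3 to compound 4 (0.18 log units; within the scatter).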

Compound 4, inhibition constant: 171 nM
For compound 4 the middle estimate is 12-fold (1.07 log units) above the measured one; the measured number lies below the stated range.
By their numbers in this assay, from the lowest: compound 1; then compound 4; then compound 2; then compound 3.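

In this assay, the same change of hydrogen to fluoro can move binding in either direction: the second fluorine strengthens it (a 7.7-fold lower number from compound 3 to compound 4 (0.88 log units; beyond the scatter)), whereas the first weakened it. The 2,4-difluorophenyl group also binds better than plain phenyl (a 3.4-fold lower number from compound 2 to compound 4 (0.53 log units; beyond the scatter)), yet the 4-fluorobenzyl group of compound 1 stays ahead (a 6.5-fold higher number from compound 1 to compound 4 (0.81 log units; beyond the scatter)). Nothing available explains why the two fluorines act in opposite directions. Open questions are whether 4-fluorophenyl on the carbonyl, without the 2-fluoro, would bind as well, and how chloro or methoxy would behave in place of the new fluoro.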